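This account rests on a few compounds, and the source may have more. Where it says the series, first, only, none or still open, it means among the compounds named here.

Measured so far in a functional assay (plasma) for inhibition, with Oryctolagus cuniculus as the target; a lower number here means a stronger inhibitor, a higher number a weaker inhibitor:
compound 1 `CCCCCCS(=O)(=O)N[C@H]1C2CC[C@H](C2)[C@@H]1C/C=C\CCCC(=O)O` gives 13300 nM
compound 2 `O=C(O)CCC/C=C\C[C@H]1[C@@H]2CCC(C2)[C@@H]1NS(=O)(=O)c1cccc2ccccc12` gives 1100 nM
compound 3 `Cc1ccc(S(=O)(=O)N[C@H]2C3CC[C@H](C3)[C@@H]2C/C=C\CCCC(=O)O)cc1` gives 500 nM

Compound 3 stands lowest of the three, with compound 2 nearest and compound 1 furthest. Compound 4 `O=C(O)CCC/C=C\C[C@H]1[C@@H]2CCC(C2)[C@@H]1NS(=O)(=O)c1ccc([N+](=O)[O-])cc1` is not yet measured; its change from compound 3 is nitro in place of methyl on an aromatic carbon. The measured steps all concern the whole group on the sulfonyl sulfur: a 12-fold lower number from compound 1 to compound 2 (1.08 log units; beyond the scatter) and a 27-fold lower number from compound 1 to compound 3 (1.42 log units; beyond the scatter), both large, and the modest 2.2-fold lower number from compound 2 to compound 3 (0.34 log units; beyond the scatter). None of them alters a substituent on a retained aromatic ring, so nothing here speaks directly to this change. The expectation is therefore for no step beyond the scatter, no change at the digits printed from compound 3 to compound 4 (within the scatter). Compound 4 is estimated at 500 nM, with a range of 150 nM to 1600 nM.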

Compound 4, half-maximal inhibitory concentration: 1400 nM
The estimate for compound 4 lay 2.8-fold (0.45 log units) below the measured number; the range from low to high includes it.
By their numbers in this assay, from the lowest: compound 3; then compounds 2 and 4 (each within the scatter of the next); then compound 1.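

In this assay, among the compounds shown here, the first change on a retained aromatic ring, nitro in place of methyl on the aromatic carbon para to a large group, does register (a 2.8-fold higher number from compound 3 to compound 4 (0.45 log units; beyond the scatter)). As whole groups on the sulfonyl sulfur, 4-nitrophenyl and naphthalen-1-yl cannot be told apart (a 1.3-fold higher number from compound 2 to compound 4 (0.10 log units; within the scatter)), while 4-nitrophenyl still clearly outperforms hexyl (a 9.5-fold lower number from compound 1 to compound 4 (0.98 log units; beyond the scatter)). No available data bear on the reason for the step from methyl to nitro.

Open: how a chlorine, a methoxy group or an amine on this carbon would compare with methyl and nitro. Also open, from the compounds shown here alone, is whether an unsubstituted phenyl would sit nearer compound 3 or compound 4.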